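The source may hold more compounds than are shown below. What is called first, only, known or untested is meant among the compounds shown, and "the series" means these compounds.

Compound 1 `Fc1ccccc1/C=C/c1ccccc1`: 700 nM
Compound 2 `Fc1cccc(/C=C/c2ccccc2F)c1`: > 15000 nM, a limit of the assay rather than a number
Compound 3 `Fc1ccc(F)c(/C=C/c2ccccc2F)c1`: 5900 nM

In an assay on HepG2 cells for activation of nuclear factor erythroid 2-related factor 2 (Homo sapiens), read by a luciferase reporter, with a stated time of 5 h (a lower number here means that less compound is needed, a higher number that more compound is needed for the effect), compound 2 stands only at the limit of > 15000 nM in this assay, at which 1 of the 3 values shown sits, so its exact place among the three cannot be fixed. Compound 4 `Fc1cccc(/C=C/c2ccc(F)cc2F)c1` differs from compound 2 by fluoro in place of hydrogen on an aromatic carbon. Two measured steps involve the same kind of change and pull in opposite directions: an at least 21-fold higher number from compound 1 to compound 2 (1.33 log units; beyond the scatter), whereas adding a fluoro to compound 2 gave a lower number in compound 3. Because an at least 2.5-fold lower number from compound 2 to compound 3 (0.40 log units; beyond the scatter) started from this same limit, a modest decrease is the expectation: an at least 1.8-fold lower number from compound 2 to compound 4 (0.27 log units; that floor lies within the scatter). Compound 4 is therefore estimated at 8000 nM, within a range of 2500 nM to 30000 nM, with a real chance that only a limit is reported again.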

Compound 4, half-maximal effective concentration: 450 nM
For compound 4 the middle estimate is 18-fold (1.25 log units) above the measured one, outside the stated range (below it).
By their numbers in this assay, from the lowest: compounds 4 and 1 (each within the scatter of the next); then compound 3. At a limit, above all of these: compound 2.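

Adding one fluoro at this aromatic carbon, meta to a fluoro group and para to a group of 9 heavy atoms, gives an at least 33-fold lower number from compound 2 to compound 4 (1.52 log units; beyond the scatter). The same kind of change at a different aromatic carbon gave an at least 2.5-fold lower number from compound 2 to compound 3 (0.40 log units; beyond the scatter), so the outcome of adding a fluoro depends on where it is placed. Both steps are only floors, because compound 2 has a limit rather than an exact number: the limit of > 15000 nM in this assay, at which 1 of the 4 values shown sits.

From the compounds shown here alone, whether this gain is specific to fluoro remains open, since a chloro, a methoxy or an amine on this carbon could behave differently. The compounds shown also do not explain why this position has such a large effect.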